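Swapping the aryl amide group on a dopamine receptor agonist

The source may report more compounds than this note shows. Statements on the series, on what has been measured and on what is new or still open speak of the compounds shown alone.

The measure here is a functional assay on HEK293 cells for agonist activity at D(4) dopamine receptor (Homo sapiens), read by FLIPR; a higher number here means a larger maximal response, a lower number a smaller maximal response. Compound 1, `O=C(CN1CCC(c2cccc[n+]2[O-])CC1)Nc1cccc(Cl)c1`, gives 76% in this assay, the highest number among the three measured compounds. Compound 3, `O=C(CN1CCC(c2cccc[n+]2[O-])CC1)Nc1cccc(-c2ccccc2)c1`, gives 75%, and the step of a number 1 percentage points lower from compound 1 to compound 3 (within the scatter) lies within the usual scatter of the method, so the two cannot be told apart. Compound 2, `Cc1cccc(NC(=O)CN2CCC(c3nccs3)CC2)c1`, differs from compound 1 in two places. In this assay compound 2 gives 62%. The gap between compound 2 and compound 1 lies beyond the scatter.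

Compound 4, `O=C(CN1CCC(c2cccc[n+]2[O-])CC1)Nc1ccccc1F`, is not yet measured. It differs from compound 1 in one place: 2-fluorophenyl in place of 3-chlorophenyl on an amide-type nitrogen. Going by the values given here, the only measured step that bears on this change is the one from compound 1 to compound 3, where the group on the same amide-type nitrogen was altered and the maximal response hardly moved, as a number 1 percentage points lower from compound 1 to compound 3 (within the scatter) shows. That single step is the whole basis for a forecast, and it speaks for a small change at most. Compound 4 is therefore expected to sit close to compound 1, with a step of a number 4 percentage points lower from compound 1 to compound 4 (within the scatter) that is estimated to stay within the scatter. The estimated value for compound 4 is 72%, with a likely range from 58% to 85%.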

Compound 4, largest response reached (reported as efficacy), in percent of the reference or control that the assay uses: 63%
The estimate for compound 4 lay 9 percentage points above the measured number; low and high end bracket the measured number.
By their numbers in this assay, from the lowest: compounds 2 and 4 (each within the scatter of the next); then compounds 3 and 1 (each within the scatter of the next).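

Replacing 3-chlorophenyl with 2-fluorophenyl on the amide-type nitrogen gives a number 13 percentage points lower from compound 1 to compound 4 (beyond the scatter) in this assay and shows that the maximal response can shift with the aryl group at this position. The earlier swap of chloro for phenyl, a number 1 percentage points lower from compound 1 to compound 3 (within the scatter), gave no sign of this, so that single tolerated change does not mean that every change of the aryl group on this nitrogen is tolerated. Nothing available here explains why this swap lowers the response while the earlier one does not.

The groups 3-chlorophenyl and 2-fluorophenyl differ both in the halogen and in where it sits on the ring, so the compounds shown cannot separate these two changes, whereas 2-chlorophenyl or 3-fluorophenyl on the same nitrogen would help to do so. Going by these compounds, it also remains open how the maximal response on the core of compound 1 would change with a different kind of substituent on this aryl ring, such as an amine, a carboxylic acid or a methoxy group.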